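Thiophen-3-yl to phenyl on a shared core

The source may hold more compounds than are shown below. What is called first, only, known or untested is meant among the compounds shown, and "the series" means these compounds.

Compound 1 `Oc1ccc(-c2cc(-c3ccsc3)nc(-c3cccc(Cl)c3)c2)cc1` was tested in an assay on isolated protein for inhibition of DNA topoisomerase 1 (Homo sapiens), with a stated time of 30 min, tested at 100 uM (on this read-out higher numbers stand for a stronger effect at the one concentration tested and lower numbers for a weaker effect), and gives 26%. Among the three compounds measured it stands second highest: compound 3 `Oc1ccc(-c2cc(-c3ccc(Cl)cc3)nc(-c3ccsc3)c2)cc1` gives 47.7%, while compound 2 `Oc1ccc(-c2cc(-c3ccsc3)nc(-c3ccccc3Cl)c2)cc1` gives 4.1%. The step of a number 21.7 percentage points higher from compound 1 to compound 3 (beyond the scatter) and the step of a number 21.9 percentage points lower from compound 1 to compound 2 (beyond the scatter) both exchange one chlorophenyl group for another while the thiophen-3-yl group is kept. Compound 4 `Oc1ccc(-c2cc(-c3ccccc3)nc(-c3cccc(Cl)c3)c2)cc1` differs from compound 1 in a different place: phenyl in place of thiophen-3-yl on an aromatic carbon. For the measured compounds named here, no measured step alters this group, so none of the steps above bears on it directly. Lacking such a precedent, the expected step of no change at the digits printed from compound 1 to compound 4 (within the scatter) is one within the scatter, with room for a shift in either direction. Compound 4 is therefore estimated at 26%, ranging from 8% to 48%.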

Compound 4, a percentage reported as inhibition, at one concentration (the size of the read-out at that concentration, not a potency): 0%
The estimate for compound 4 lay 26 percentage points above the measured number; the whole stated range lies above it.
By their numbers in this assay, from the lowest: compounds 4 and 2 (each within the scatter of the next); then compound 1; then compound 3.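

Phenyl in place of thiophen-3-yl gives a number 26 percentage points lower from compound 1 to compound 4 (beyond the scatter), the first sign that the group next to the ring nitrogen matters in this assay, since the earlier steps changed only the chlorophenyl group. The read-out therefore responds to a change at this position as well as to changes in that group. Nothing measured here accounts for this step.

From the compounds shown here alone, whether the same exchange would have a similar effect alongside the 4-chlorophenyl group of compound 3 remains open. Also open, going by these compounds, is what a furan-3-yl ring or an amine would give at this position.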